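A few compounds are considered here, and "the series" means these few. Any claim that something is new, unique, unknown or untested is made for them only; others in the source may bear on it.

The series shares a core in which compound 1 `O=[N+]([O-])c1ccc2nc(Nc3ccccc3)c(Nc3ccccc3)nc2c1` and compound 3 `O=[N+]([O-])c1ccc2nc(Nc3cccc(Cl)c3)c(Nc3cccc(Cl)c3)nc2c1` carry a nitro group, while compound 2 `O=C(Nc1ccc2nc(Nc3ccc(Cl)c(Cl)c3)c(Nc3ccc(Cl)c(Cl)c3)nc2c1)c1cccc(C(F)(F)F)c1` and compound 4 `O=C(Nc1ccc2nc(Nc3ccc(Cl)c(Cl)c3)c(Nc3ccc(Cl)c(Cl)c3)nc2c1)c1ccco1` carry an amide at the same place on the core. In a toxicity assay on HepG2 cells (Homo sapiens) for cytotoxicity, read by MTT assay, with a stated time of 24 h (a lower number here means that less compound is tolerated, a higher number that more compound is tolerated), compound 1 gives 12600 nM and compound 3 gives 6760 nM, two values that sit close to each other, so no ordering between them can be read from these numbers. For compound 2 the entry in this assay reads "nd" (no result reported), so it stands without a number; the account of the change to compound 4 therefore has no starting value to lean on.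

The structural change is furan-2-yl in place of 3-(trifluoromethyl)phenyl on a carbonyl carbon. Going by the values given here, since no measured pair frames a step of this kind, the size of the move in this assay cannot be drawn from the data; the only anchors are the two nitro compounds, whose values lie in the same region of the scale. On that basis the expectation for compound 4 is a tolerance of the same order as compound 1 and compound 3, with no shift beyond the usual scatter that could be predicted with confidence in either direction. Compound 4 is estimated at 10000 nM, with a range from 3000 nM to 40000 nM.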

Compound 4, half-maximal cytotoxic concentration: 14800 nM
Estimate against measurement, compound 4: 1.5-fold (0.17 log units) below, and the stated range covers the measured number.
By their numbers in this assay, from the lowest: compounds 3, 1 and 4 (each within the scatter of the next, the first and the last beyond it).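

Going by these compounds alone, with compound 2 standing without a number in this assay, the change from compound 2 to compound 4 yields no step that can be read. The compounds shown leave open how furan-2-yl in place of 3-(trifluoromethyl)phenyl on a carbonyl carbon shifts the tolerated concentration in this assay. No supporting evidence bears on the result of compound 4.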